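The compounds below may be only part of what the source reports. "The series", "measured", "known", "first", "only" and "open" are said of these compounds alone.

Working notes on the series.

Compound 2 `COc1ccc(-c2csc(N)c2C(=O)OCc2ccccc2C)cc1OC` stands highest of the two numbers in hand in an assay on isolated protein for inhibition of protein kinase C zeta type (Homo sapiens), with stated times of 1 h and 2.5 min, tested at 30 uM (on this read-out higher numbers stand for more inhibition at the one concentration tested (going by the name of the read-out) and lower numbers for less inhibition), giving 64%. Its nearest neighbour is compound 1 `COCC(C)OC(=O)c1c(-c2ccc(OC)c(OC)c2)csc1N`, which in this assay gives 49%; the step of a number 15 percentage points higher from compound 1 to compound 2 (beyond the scatter) came with a change of the ester group on the oxygen next to the carbonyl group. Compound 3 `COc1ccc(-c2csc(N)c2C(=O)OCc2ccc(C)cc2)cc1OC` is not yet measured. It differs from compound 2 as follows: 4-methylphenyl in place of 2-methylphenyl on a saturated chain carbon bound to an oxygen next to a carbonyl group. Within the data shown here, no measured step bears directly on moving the methyl from one position of the benzyl ring to another; the single step in hand, a number 15 percentage points higher from compound 1 to compound 2 (beyond the scatter), concerns a different kind of change and is only modest. With the ring, chain and all counted atoms unchanged, no step beyond the scatter is expected, so the estimated step is a number 2 percentage points lower from compound 2 to compound 3 (within the scatter). In this assay compound 3 is therefore expected to give about 62%, with a range from 45% to 78%.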

Compound 3, a percentage reported as inhibition, at one concentration (the size of the read-out at that concentration, not a potency): 50%
Estimate against measurement, compound 3: 12 percentage points above; low and high end bracket the measured number.
By their numbers in this assay, from the lowest: compounds 1 and 3 (each within the scatter of the next); then compound 2.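

Working notes, continued. In this assay, moving the methyl on the benzyl ring is not a neutral change: the step is a number 14 percentage points lower from compound 2 to compound 3 (beyond the scatter), with 4-methylphenyl in place of 2-methylphenyl and the same heavy atoms on both sides. The earlier rise on going to the 2-methylbenzyl ester therefore does not extend to every methylbenzyl ester, since the step to the 4-methylbenzyl ester is a number 1 percentage points higher from compound 1 to compound 3 (within the scatter), and among these three compounds only compound 2 stands apart. Nothing in hand gives a reason for this difference.

The compounds shown leave open whether the effect belongs to the methyl group itself or to any group at that place, and an unsubstituted benzyl, a 3-methylbenzyl or a 2-chlorobenzyl ester would bear on this. All three readings come from one concentration, so they describe inhibition at that concentration and not potency.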